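Fluorosulfonylphenyl urea series: shifting the sulfonyl fluoride

The source may hold more compounds than are shown below. What is called first, only, known or untested is meant among the compounds shown, and "the series" means these compounds.

Measured so far in an assay on isolated protein for inhibition of Dihydrofolate reductase (Mus musculus); on this read-out lower numbers stand for lower potency and higher numbers for higher potency (the scale is a negative logarithm):
compound 1 `CC1(C)N=C(N)N=C(N)N1c1ccc(OCCCNC(=O)Nc2ccc(S(=O)(=O)F)cc2)c(Cl)c1` gives 7.68
compound 2 `Cc1cc(NC(=O)NCCCOc2ccc(N3C(N)=NC(N)=NC3(C)C)cc2Cl)ccc1S(=O)(=O)F` gives 8.06
compound 3 `CC1(C)N=C(N)N=C(N)N1c1ccc(OCc2ccc(C(=O)Nc3ccc(S(=O)(=O)F)cc3)cc2)c(Cl)c1` gives 6.92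

Compound 2 holds the highest of the three numbers: compound 1 lies nearer, compound 3 furthest. Among the measured compounds shown here, the one single-site step in hand is a number 0.38 log units higher from compound 1 to compound 2 (beyond the scatter), a modest gain beyond the scatter.

Compound 4 `CC1(C)N=C(N)N=C(N)N1c1ccc(OCCCNC(=O)Nc2cccc(S(=O)(=O)F)c2)c(Cl)c1` is now to be measured in this assay. Against compound 2 the change is a group of 10 heavy atoms (6 carbon, 2 oxygen, 1 fluorine, 1 sulfur; one six-membered aromatic ring of carbon only) in place of a group of 11 heavy atoms (7 carbon, 2 oxygen, 1 fluorine, 1 sulfur; one six-membered aromatic ring of carbon only), on an amide-type nitrogen. For the measured compounds named here, no measured step covers this exact swap, but it removes the methyl whose addition gave a number 0.38 log units higher from compound 1 to compound 2 (beyond the scatter), so part of that gain is expected to be lost, with the new ring placement carrying unknown further effect. Compound 4 is therefore estimated at 7.6, range 7 to 8.2, corresponding to an expected step of a number 0.46 log units lower from compound 2 to compound 4 (beyond the scatter).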

Compound 4, logarithm of the reciprocal of the active concentration, log(1/C): 7.28
Estimate against measurement, compound 4: 0.32 log units above, within the range that was stated.
By their numbers in this assay, from the lowest: compound 3; then compound 4; then compound 1; then compound 2.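

In this assay the placement of the sulfonyl fluoride matters on its own: 3-(fluorosulfonyl)phenyl in place of 4-(fluorosulfonyl)phenyl gives a number 0.40 log units lower from compound 1 to compound 4 (beyond the scatter) with nothing else changed. The larger a number 0.78 log units lower from compound 2 to compound 4 (beyond the scatter) combines that shift with loss of the methyl, and the two contributions cannot be separated here. No measurement in hand accounts for either step.

Still open, on these data alone, is whether a methyl added to the 3-(fluorosulfonyl)phenyl group brings a gain like the one seen with the 4-(fluorosulfonyl)phenyl group. Also open, as far as these compounds go, is whether a carboxylic acid or a nitrile can stand in place of the sulfonyl fluoride.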